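Towards a Dichlorophenyl Analogue in the Ehrlich Cell Series

The compounds below may be only part of what the source reports. "The series", "measured", "known", "first", "only" and "open" are said of these compounds alone.

Three compounds sharing one core have so far been run in a functional assay on Ehrlich cells (Mus musculus) for cytotoxicity, read by trypan blue exclusion, with a stated time of 2 h, tested at 10 ug/mL; on this read-out lower numbers stand for a weaker effect and higher numbers for a stronger effect at the one concentration tested. Compound 1 `N#CC1=C(N)N(c2ccc(S(N)(=O)=O)cc2)C2=C(CCCC2)C1c1ccccc1O` gives 10% in this assay. Compound 2 `N#CC1=C(N)N(c2ccc(S(N)(=O)=O)cc2)C2=C(CCCC2)C1/C=C/c1ccccc1` gives 50% in this assay. Compound 3 `N#CC1=C(N)N(c2ccc(S(N)(=O)=O)cc2)C2=C(CCCC2)C1c1cccc([N+](=O)[O-])c1` gives 0% in this assay, the lowest of the three numbers. The nearest number belongs to compound 1 and the furthest to compound 2; as steps, a number 10 percentage points lower from compound 1 to compound 3 (within the scatter), whereas a number 50 percentage points lower from compound 2 to compound 3 (beyond the scatter). The remaining pair shows a number 40 percentage points higher from compound 1 to compound 2 (beyond the scatter).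

Compound 4 `N#CC1=C(N)N(c2ccc(S(N)(=O)=O)cc2)C2=C(CCCC2)C1c1ccc(Cl)cc1Cl` has not yet been measured. It differs from compound 3 in one place: 2,4-dichlorophenyl in place of 3-nitrophenyl on a saturated ring carbon.

Within the data shown here, two measured steps bear on this exchange, both altering the group on the same saturated ring carbon and both ending at compound 3. The large one, from compound 2, swapped 2-phenylethenyl for 3-nitrophenyl. The small one, from compound 1, swapped one substituted phenyl for another. The closer precedent is the latter because a number 10 percentage points lower from compound 1 to compound 3 (within the scatter) and compound 4 again bears a substituted phenyl, so only a modest step is expected in this assay, most likely upward: a number 15 percentage points higher from compound 3 to compound 4 (beyond the scatter). Compound 4 is therefore estimated at 15%, within a range from 0% to 40%.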

Compound 4, a percentage reported as activity, at one concentration (the size of the read-out at that concentration, not a potency): 0%
Compound 4: the middle estimate sits 15 percentage points above what was measured, and the stated range covers the measured number.
By their numbers in this assay, from the lowest: compounds 3, 4 and 1 (each within the scatter of the next); then compound 2.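

In this assay, the exchange on this saturated ring carbon gives no change at the digits printed from compound 3 to compound 4 (within the scatter), so moving from 3-nitrophenyl, with 2 hydrogen-bond acceptors, to 2,4-dichlorophenyl, with 0, leaves the read-out where it was. Compound 4 also falls in with the 2-hydroxyphenyl compound, at a number 10 percentage points lower from compound 1 to compound 4 (within the scatter), but stands well apart from the 2-phenylethenyl compound, at a number 50 percentage points lower from compound 2 to compound 4 (beyond the scatter); the three compounds with a substituted phenyl directly on this carbon thus lie within the scatter of one another, none of them goes against this grouping, and compound 2 alone stands clear of them. Nothing measured here accounts for this grouping or for the separate place of compound 2.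

The compounds shown leave open whether the higher number of compound 2 depends on the double bond of its 2-phenylethenyl group, on its terminal phenyl ring, or on both, a question that a saturated 2-phenylethyl chain or a simple propenyl group at this carbon would address. They also leave open whether an unsubstituted phenyl or a pyridyl ring on this carbon would stay with the substituted phenyls or move towards compound 2.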